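A Charged Group on the Side Chain of Compound 2

This account rests on a few compounds, and the source may have more. Where it says the series, first, only, none or still open, it means among the compounds named here.

Measured in a functional assay on HepG2 cells (Homo sapiens) for cytotoxicity, read by MTT assay, with a stated time of 48 h; a lower number here means a stronger inhibitor, a higher number a weaker inhibitor:
Compound 1 `CC1=NN(C(=O)CN2CCCCC2)C(c2ccccc2O)C1`: 3020 nM
Compound 2 `COc1ccccc1C1CC(C)=NN1C(=O)CN1CCC(OC)CC1`: 22000 nM

Compound 2, at 22000 nM, has the higher of the two numbers, and compound 1, at 3020 nM, has the lower; the gap lies beyond the usual scatter. These two compounds differ in more than one place, so the gap offers no guide to any single change.

Compound 3 `CC[N+](C)(CC)CC(=O)N1N=C(C)CC1c1ccccc1OC` has not yet been measured. It departs from compound 2 in one place: a group of 6 heavy atoms (5 carbon, 1 nitrogen; no ring) in place of a group of 8 heavy atoms (6 carbon, 1 nitrogen, 1 oxygen; one six-membered non-aromatic ring with 1 hetero atom), on a saturated chain carbon bound to a carbonyl carbon. The 4-methoxypiperidin-1-yl group leaves, and a group with no ring and net charge +1 enters, on a saturated chain carbon bound to a carbonyl carbon.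

Among the compounds with values here, no measured pair shows this kind of change, so the expectation in this assay is loose: a small step toward a higher number. The expected step is a 1.8-fold higher number from compound 2 to compound 3 (0.26 log units; within the scatter). For compound 3 the estimated value is 40000 nM, with an expected range from 10000 nM to 150000 nM.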

Compound 3, half-maximal inhibitory concentration: 3670 nM
Beside the measured number, compound 3's estimate is 11-fold (1.04 log units) above it; the measured number lies below the stated range.
By their numbers in this assay, from the lowest: compounds 1 and 3 (each within the scatter of the next); then compound 2.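

In this assay, the saturated chain carbon bound to a carbonyl carbon proves to be a place where a single change moves the number: with the 4-methoxypiperidin-1-yl group replaced by a group with no ring and net charge +1, the result is a 6.0-fold lower number from compound 2 to compound 3 (0.78 log units; beyond the scatter). This only single-place step shown indicates that the six-membered ring is not required here for a number lower than that of compound 2, and that a group with net charge +1 is compatible with activity in this assay. No measurement offered here explains why the number falls.

The compounds shown leave open whether the step follows the loss of the ring, the gain of the charge, or both. A neutral diethylamino group on the same carbon would separate these two changes, while a carboxylic acid there would test a different kind of group.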